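Sulfonyl substituent change in the chromene series

The source may report more compounds than this note shows. Statements on the series, on what has been measured and on what is new or still open speak of the compounds shown alone.

Compound 1 `CNS(=O)(=O)c1ccc2c(c1)C(n1ccccc1=O)=CC(C)(C)O2` and compound 2 `CN(C)S(=O)(=O)c1ccc2c(c1)C(n1ccccc1=O)=CC(C)(C)O2` form the shared core. In a functional assay with Rattus norvegicus as the target (a lower number here means that less compound is needed, a higher number that more compound is needed for the effect), compound 1 gives 17.8 nM and compound 2 gives 16.2 nM; compound 2 has the lowest of the two numbers, its nearest neighbour being compound 1, a gap within the scatter. Going by the values given here, the only measured step, a 1.1-fold lower number from compound 1 to compound 2 (0.04 log units; within the scatter), touched the sulfonamide nitrogen. Among the compounds with values here, compound 3 `CC1(C)C=C(n2ccccc2=O)c2cc(S(=O)(=O)Oc3ccccc3)ccc2O1` differs from compound 2 by phenoxy in place of dimethylamino on a sulfonyl sulfur, a larger change on the same sulfonyl group, for which no measured step stands in. Compound 3 is expected to give 22 nM in this assay, range 8 nM to 70 nM, with the estimated step of a 1.4-fold higher number from compound 2 to compound 3 (0.13 log units; within the scatter) not beyond the scatter.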

Compound 3, half-maximal effective concentration: 2.51 nM
Compound 3: middle estimate off by 8.8-fold (0.94 log units), on the high side; measured number outside the range, below it.
By their numbers in this assay, from the lowest: compound 3; then compounds 2 and 1 (each within the scatter of the next).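

On the sulfonyl sulfur, the group itself matters in a way the sulfonamide nitrogen step did not reveal: in this assay, phenoxy gives a 6.5-fold lower number from compound 2 to compound 3 (0.81 log units; beyond the scatter) and a 7.1-fold lower number from compound 1 to compound 3 (0.85 log units; beyond the scatter), both beyond the scatter. Compound 3 therefore stands clear of both sulfonamides, which stay within the scatter of each other. No evidence on hand accounts for this shift. Phenoxy brings an oxygen and an aromatic ring together, and the compounds shown do not separate the two. A phenylamino or benzyl group on the sulfonyl sulfur would bear on that.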